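Predicting a 1-(4-fluorophenyl)ethyl amide in the SK-BR-3 cytotoxicity assay

The source may hold more compounds than are shown below. What is called first, only, known or untested is meant among the compounds shown, and "the series" means these compounds.

This account concerns a short series sharing one core and tested in a functional assay on SK-BR-3 cells (Homo sapiens) for cytotoxicity, read by MTT assay, with a stated time of 72 h; on this read-out higher numbers stand for weaker inhibition and lower numbers for stronger inhibition. Compound 1 `COc1cccc(CNC(=O)c2nc(Br)c3cccnc3c2N[C@H]2CC[C@H](N)CC2)c1` gives 6000 nM in this assay, the highest of the three numbers measured. Compound 2 `COC(=O)CNc1c(C(=O)NCc2ccc(F)cc2)nc(Br)c2cccnc12` gives 1000 nM, and compound 3 `CNCCCNc1c(C(=O)NCc2ccc(F)cc2)nc(Br)c2cccnc12` gives 1000 nM; both stand at a lower number than compound 1, with the gap to each beyond the scatter. For the measured compounds named here, the one measured step, no change at the digits printed from compound 2 to compound 3 (within the scatter), concerns the other nitrogen on the core and does not touch the amide side.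

Compound 4 `C[C@H](NC(=O)c1nc(Br)c2cccnc2c1N[C@H]1CC[C@H](N)CC1)c1ccc(F)cc1` differs from compound 1 by 1-(4-fluorophenyl)ethyl in place of 3-methoxybenzyl on an amide-type nitrogen. Going by the values given here, no measured step bears on this change directly. Compounds 2 and 3, which carry a 4-fluorobenzyl amide, sit well below compound 1, but they also differ elsewhere, so only their values, not a step, can be read. On that basis compound 4 is expected to improve, with a 3.0-fold lower number from compound 1 to compound 4 (0.48 log units; beyond the scatter) judged likely to lie beyond the scatter. The estimate for compound 4 in this assay is 2000 nM, expected between 600 nM and 6000 nM.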

Compound 4, half-maximal inhibitory concentration: 9000 nM
Compound 4: the middle estimate sits 4.5-fold (0.65 log units) below what was measured; measured number above the stated range.
By their numbers in this assay, from the lowest: compounds 2 and 3 (each within the scatter of the next); then compounds 1 and 4 (each within the scatter of the next).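

In this assay, for the compounds shown here, the first measured step at the amide-type nitrogen is a 1.5-fold higher number from compound 1 to compound 4 (0.18 log units; within the scatter), so exchanging 3-methoxybenzyl for 1-(4-fluorophenyl)ethyl leaves the number within the scatter while the rest of compound 1 stays fixed. At this position, then, losing the methoxy oxygen and gaining fluorine and a defined stereocentre together produce no change that can be told from the scatter. No evidence at hand accounts for this result.

The compounds shown leave open how the ring fluorine, the loss of the methoxy group and the added methyl branch would each read alone, as their contributions appear here only together. Also open, from the compounds shown here alone, is whether a plain benzyl or a longer chain such as 2-phenylethyl on that nitrogen would read differently in this assay.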